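Acetate and fluoro-imidazole variants on the quinolinol core

The source may hold more compounds than are shown below. What is called first, only, known or untested is meant among the compounds shown, and "the series" means these compounds.

Measured compounds in a functional assay on MM1.S cells (Homo sapiens) for antiproliferative activity, read by luminescence, with a stated time of 72 h; a lower number here means a stronger inhibitor, a higher number a weaker inhibitor:
- compound 1 `CC(C)(CCl)C(=O)Oc1ccc(Cn2ccnc2)c2cccnc12` gives 3600 nM
- compound 2 `Cc1cc2ncn(Cc3ccc(O)c4ncccc34)c2cc1C` gives "not determined" (no result reported), that is, no result reported
- compound 3 `CC(=O)Oc1ccc(Cn2ccnc2)c2cccnc12` gives "not determined" (no result reported), that is, no result reported

For the measured compounds named here, compound 3 therefore stands without a number in this assay, as does compound 2; the only value on record is that of compound 1. Compound 4 `CC(=O)Oc1ccc(Cn2cnc(F)c2)c2cccnc12` differs from compound 3 in one place: fluoro in place of hydrogen on an aromatic carbon. Going by the values given here, no pair with a measured step exists in this set, so the size of the step from compound 3 to compound 4 in this assay cannot be read from the data. The expectation is a step of no more than the scatter in either direction, with the value of compound 1 as the only anchor for the series. Compound 4 is estimated at 3500 nM in this assay, within a range of 800 nM to 15000 nM, and this estimate rests on compound 1 giving 3600 nM rather than on any measurement of compound 3.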

Compound 4, half-maximal inhibitory concentration: 1100 nM
Compound 4: the middle estimate sits 3.2-fold (0.50 log units) above what was measured, within the range that was stated.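

For the compounds shown here, compound 3 stands without a number in this assay, so no step from compound 3 to compound 4 can be read. The compounds shown leave open what fluoro in place of hydrogen on that aromatic carbon does in this read-out. No further data here bear on the result for compound 4.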